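Removing the Methoxy Group: What to Expect for Compound 4

The source may hold more compounds than are shown below. What is called first, only, known or untested is meant among the compounds shown, and "the series" means these compounds.

Measured compounds:
Compound 1 `COc1cccc(CNC(=O)c2nc(Br)c3cccnc3c2N[C@H]2CC[C@H](N)CC2)c1`: 6000 nM
Compound 3 `COc1ccc(CNC(=O)c2nc(Br)c3cccnc3c2N[C@H]2CC[C@H](N)CC2)cc1`: 3000 nM
Compound 2 `N[C@H]1CC[C@H](Nc2c(C(=O)NCc3cccc(C(F)(F)F)c3)nc(Br)c3cccnc23)CC1`: "not determined" (no result reported)

In a functional assay on HCT-116 cells (Homo sapiens) for cytotoxicity, read by MTT assay, with a stated time of 72 h (a lower number here means a stronger inhibitor, a higher number a weaker inhibitor), compound 3 gives 3000 nM and compound 1 gives 6000 nM; these two numbers lie within the usual scatter of each other, so neither can be called the stronger inhibitor on this evidence. Compound 2, with a trifluoromethyl group in place of the methoxy, has no result in this assay.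

Compound 4 `N[C@H]1CC[C@H](Nc2c(C(=O)NCc3ccccc3)nc(Br)c3cccnc23)CC1` differs from compound 3 in one place: hydrogen in place of methoxy on an aromatic carbon.

For the measured compounds named here, the only measured step, a 2.0-fold lower number from compound 1 to compound 3 (0.30 log units; within the scatter), moved the methoxy group from one ring position to another rather than removing it, and it stayed within the scatter. Going by the values given here, no measured pair shows what removing the methoxy group does, so the expectation rests on the small effect of that one step. The change is expected to move the number by a 1.5-fold higher number from compound 3 to compound 4 (0.18 log units; within the scatter), which is no more than the scatter. Compound 4 is therefore estimated at 4500 nM, with a range of 1500 nM to 15000 nM.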

Compound 4, half-maximal inhibitory concentration: 7000 nM
Estimate against measurement, compound 4: 1.6-fold (0.19 log units) below; measured number inside the range.
By their numbers in this assay, from the lowest: compounds 3, 1 and 4 (each within the scatter of the next, the first and the last beyond it).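

Removing the methoxy group from the 4-methoxyphenyl ring gives a 2.3-fold higher number from compound 3 to compound 4 (0.37 log units; beyond the scatter) in this assay, a modest step but the first in this series to clear the scatter, which moving the group between ring positions did not do. The same removal from the 3-methoxyphenyl ring gives a 1.2-fold higher number from compound 1 to compound 4 (0.07 log units; within the scatter), so in these compounds losing the methoxy group registers only when it starts from the 4-methoxyphenyl form. Nothing available here accounts for this difference between the two starting compounds.

The compounds shown leave open whether the gain belongs to methoxy itself or would also appear with another group in that place, such as a hydroxyl, a fluorine atom or an amine. They also leave open how a longer chain between the amide nitrogen and the ring would change the number.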